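The compounds below may be only part of what the source reports. "The series", "measured", "known", "first", "only" and "open" are said of these compounds alone.

Working notes on the series. Compound 1 `Cn1c(=O)cnn(CCCCN2CCN(c3ccccc3)CC2)c1=O` gives 64 nM in an assay for displacement of a labelled ligand from Adrenergic receptor alpha-1 (Homo sapiens); a higher number here means a weaker inhibitor, a lower number a stronger inhibitor. Compound 3 `Cn1c(=O)cnn(CCCCN2CCN(c3ccccn3)CC2)c1=O` gives 262 nM in this assay, and the step of a 4.1-fold higher number from compound 1 to compound 3 (0.61 log units; beyond the scatter) is modest. Compound 2 `Cn1c(=O)cnn(CCCCN2CCN(c3cccc(O)c3)CC2)c1=O` reaches only > 10000 nM in this assay, which is a limit of the assay and not a number (the limit of > 10000 nM in this assay, at which 1 of the 3 values shown sits). The step of an at least 150-fold higher number from compound 1 to compound 2 (2.19 log units; beyond the scatter) is large, as is the step of an at least 38-fold lower number from compound 2 to compound 3 (1.58 log units; beyond the scatter). Among the two real numbers, compound 3 stands highest, with compound 1 as the nearest neighbour.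

Compound 4 `Cn1c(=O)cnn(CCCCN2CCN(c3ccc(F)cn3)CC2)c1=O` is not yet measured. It differs from compound 3 by fluoro in place of hydrogen on an aromatic carbon. Going by the values given here, no measured step adds a fluoro to any ring; the only substituent addition seen, the hydroxy on the phenyl of compound 2, gave a large loss, but it concerns a different group on a different ring and carries hydrogen-bond donors where the fluoro carries none. The step from compound 3 to compound 4 is therefore expected to be small, near or within the scatter, in either direction, as a 1.1-fold higher number from compound 3 to compound 4 (0.06 log units; within the scatter). Compound 4 is expected to give about 300 nM in this assay, within 100 nM to 1000 nM.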

Compound 4, inhibition constant: > 10000 nM
Compound 4 was reported as a limit; the forecaster's own chance of this, stated with the estimate: 5%; middle value at least 33-fold (1.52 log units) from the limit.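

A single fluorine atom, on an aromatic carbon two atoms from the ring nitrogen and para to a large group, is enough for an at least 38-fold higher number from compound 3 to compound 4 (1.58 log units; beyond the scatter) in this assay. So this position on the pyridin-2-yl ring, untested by the earlier compounds, is highly sensitive to this small change, and the comparison with the unsubstituted phenyl gives an at least 150-fold higher number from compound 1 to compound 4 (2.19 log units; beyond the scatter). The entry for compound 4 is a limit of the assay and not a number: the limit of > 10000 nM in this assay, at which 2 of the 4 values shown sit.

The two limits leave the step between compound 2 and compound 4 unreadable. As far as these compounds go, it remains open whether the loss is specific to fluoro or extends to other groups at this position, such as chloro or methyl, and whether a fluoro on the phenyl of compound 1 would behave the same way.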